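This account rests on a few compounds, and the source may have more. Where it says the series, first, only, none or still open, it means among the compounds named here.

Compound 1 `COc1ccc(OC)c(S(=O)(=O)NC(=O)c2ccc(Cn3ccc4ccc(NC(=O)CC5CCCC5)cc43)c(OC)c2)c1` gives 9.1 in a functional assay (trachea) for antagonist activity, with Cavia porcellus as the target; a lower number here means a less potent compound, a higher number a more potent compound, by a factor of ten per unit of this negative logarithm. Compound 2 `COc1cc(C(=O)NS(=O)(=O)c2c(C)cccc2Cl)ccc1Cn1ccc2ccc(NC(=O)CC3CCCC3)cc21` gives 8.8 in this assay and so stands within the scatter of compound 1, since a number 0.30 log units lower from compound 1 to compound 2 (within the scatter). Compound 3 `COc1cc(C(=O)NS(=O)(=O)c2ccccc2N)ccc1Cn1ccc2ccc(NC(=O)CC3CCCC3)cc21` differs from compound 2 in one place: 2-aminophenyl in place of 2-chloro-6-methylphenyl on a sulfonyl sulfur. Within the data shown here, only one measured step bears on this change, the exchange of the ring on a sulfonyl sulfur between compound 1 and compound 2, and that step stayed within the scatter. A step of similar size, no change at the digits printed from compound 2 to compound 3 (within the scatter), is therefore expected, with no clear direction. Compound 3 is estimated at 8.8 in this assay, between 8.1 and 9.4.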

Compound 3, negative logarithm of the antagonist equilibrium constant: 9.9
Estimate against measurement, compound 3: 1.10 log units below; measured number above the stated range.
By their numbers in this assay, from the lowest: compounds 2 and 1 (each within the scatter of the next); then compound 3.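

In this assay, the ring on the sulfonyl sulfur proves able to shift potency well past the scatter: 2-aminophenyl gives a number 1.10 log units higher from compound 2 to compound 3 (beyond the scatter), and it also gives a number 0.80 log units higher from compound 1 to compound 3 (beyond the scatter). Among these compounds, the one earlier exchange at this position stayed within the scatter, so only now is this position seen to respond to the ring it carries. Nothing measured here says why the 2-aminophenyl ring gives the higher number. Still open, going by these compounds, is whether a hydroxyl or a methylamino group in place of the amino group would keep this gain.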